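The source may report more compounds than this note shows. Statements on the series, on what has been measured and on what is new or still open speak of the compounds shown alone.

Among the compounds with values here, in a functional assay on the whole organism with Canis familiaris (Canis lupus familiaris) as the target (on this read-out lower numbers stand for an effect already at smaller amounts and higher numbers for an effect only at larger amounts of compound), compound 1 `c1ccc(-c2nc3cc[nH]cc-3n2)cc1` gives 2.5 mg/kg and compound 2 `COc1ccc(-c2nc3cc[nH]cc-3n2)cc1` gives 1.7 mg/kg as the second of only two numbers, the pair lying within the scatter of each other. Compound 3 `COc1ccc(-c2nc3cc[nH]cc-3n2)cc1OC` carries a further methoxy in place of hydrogen on an aromatic carbon of compound 2, ortho to a methoxy group (methoxy in place of hydrogen on an aromatic carbon). Within the data shown here, the one measured step of this kind is a 1.5-fold lower number from compound 1 to compound 2 (0.17 log units; within the scatter) and it is the only guide, so no change beyond the scatter is expected in this assay here. The expected step is a 1.1-fold lower number from compound 2 to compound 3 (0.03 log units; within the scatter) and it rests on that single precedent. Compound 3 is estimated at 1.6 mg/kg with an expected range of 0.7 mg/kg to 3.6 mg/kg in this series.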

Compound 3, dose for half-maximal effect: 0.4 mg/kg
For compound 3 the middle estimate is 4.0-fold (0.60 log units) above the measured one; the whole stated range lies above it.
By their numbers in this assay, from the lowest: compound 3; then compounds 2 and 1 (each within the scatter of the next).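

In this assay, methoxy in place of hydrogen on an aromatic carbon gives a step beyond the scatter at this place, ortho to a methoxy group and meta to a group of 9 heavy atoms: a 4.3-fold lower number from compound 2 to compound 3 (0.63 log units; beyond the scatter). The same kind of change earlier gave only a 1.5-fold lower number from compound 1 to compound 2 (0.17 log units; within the scatter), so the replacement does not give a step of one size across the series. No measurement on hand bears on the reason for this step.

From the compounds shown here alone, whether this place needs the neighbouring methoxy group stays open. Also open, going by these compounds, is how a hydroxy group, an ethoxy group or an amine would read out here.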